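This account rests on a few compounds, and the source may have more. Where it says the series, first, only, none or still open, it means among the compounds named here.

Compounds measured so far:
compound 1 `CC1(C(=O)NCCSc2nonc2/C(=N/O)Nc2ccc(F)c(C(F)F)c2)CCN1`: > 3 h
compound 2 `C[C@@H](CSc1nonc1/C(=N/O)Nc1ccc(F)c(Br)c1)NC(=O)CS(N)(=O)=O`: > 3 h
compound 3 `NS(=O)(=O)CC(=O)NCCSc1nonc1/C(=N/O)Nc1cccc(Br)c1`: 0.955 h

In an ADME assay on isolated protein for pharmacokinetics, with UDP-glucuronosyltransferase 1A9 (Homo sapiens) as the target, read by LC-MS, with a stated time of 60 min, at 37 degrees C, tested at 1 uM, in the presence of a further agent that is not named here (on this read-out lower numbers stand for a shorter-lived compound and higher numbers for a longer-lived compound), compound 1 gives no number but a limit of the assay, > 3 h. Compound 2 likewise gives only a limit, > 3 h. Among the compounds with values here, compound 3 is the one compound with a number, 0.955 h, so compound 1 stands at the upper end of what the set shows, at the limit of > 3 h in this assay, at which 2 of the 3 values shown sit.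

Compound 4 `CS(=O)(=O)CC(=O)NCCSc1nonc1/C(=N/O)Nc1ccc(F)c(C(F)F)c1` is not yet measured. It differs from compound 1 in one place: a group of 5 heavy atoms (2 carbon, 2 oxygen, 1 sulfur; no ring) in place of a group of 5 heavy atoms (4 carbon, 1 nitrogen; one four-membered non-aromatic ring with 1 hetero atom), on a carbonyl carbon. Within the data shown here, no measured pair shows this change, and a starting value that is only a limit gives no firm footing. The step from compound 1 to compound 4 is expected to be a modest shortening, an at least 1.5-fold lower number from compound 1 to compound 4 (0.17 log units; that floor lies within the scatter), though a value at the limit again would not surprise. For compound 4 the estimate in this assay is 2 h, between 0.9 h and 3.5 h.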

Compound 4, half-life: 1.59 h
Beside the measured number, compound 4's estimate is 1.3-fold (0.10 log units) above it, within the range that was stated.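

Within the data shown here, on the carbonyl carbon, the (methylsulfonyl)methyl group of compound 4 gives a number in this assay, whereas the group it replaces had given only a limit, something the earlier compounds could not show for this position. As far as these compounds go, compound 1 stands at a limit of the assay, > 3 h, and it is not alone there: the limit of > 3 h in this assay, at which 2 of the 4 values shown sit. The step therefore reads as an at least 1.8-fold lower number from compound 1 to compound 4 (0.27 log units; that floor lies within the scatter), which is only a floor, so its full size stays unknown.

From the compounds shown here alone, it remains open whether this change would read the same with other substituents on the shared core. Going by these compounds, it is also open whether a plain open-chain amine or a carboxylic acid on this carbonyl carbon would give a number, as compound 4 does, or a limit, as compound 1 does.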